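The source may report more compounds than this note shows. Statements on the series, on what has been measured and on what is new or still open speak of the compounds shown alone.

Measured compounds:

Compound 1, `Cc1cc(O)c(C(c2cn([C@H]3C[C@H](O)[C@@H](CO)O3)c(=O)[nH]c2=O)c2c(O)cc(C)n(C)c2=O)c(=O)n1C`. In an ADME assay on HEL cells (Homo sapiens) for cytotoxicity, read by microscopy (on this read-out lower numbers stand for higher toxicity in this test and higher numbers for lower toxicity in this test), compound 1 gives > 100000 nM, which is a limit of the assay and not a number.

Compound 2, `CCn1c(C)cc2c(c1=O)C(c1cn([C@H]3C[C@H](O)[C@@H](CO)O3)c(=O)[nH]c1=O)C(C#N)=C(N)O2`. In this assay compound 2 gives > 100000 nM, again a limit of the assay and not a number.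

Where compound 2 stands: both values shown sit at the limit of > 100000 nM in this assay, at which 2 of the 2 values shown sit, so compound 2 is not set apart from compound 1 on these numbers; neither compound has a numerical read-out in this assay, and no step between measured compounds is available.

Compound 3, `Cc1cc2c(c(=O)n1C)C(c1cn([C@H]3C[C@H](O)[C@@H](CO)O3)c(=O)[nH]c1=O)C(C#N)=C(N)O2`, is the next member to be measured. It differs from compound 2 by hydrogen in place of methyl on a saturated chain carbon bound to an aromatic nitrogen; cut one bond further out, the same difference reads ethyl to methyl. The rest of the shared core is unchanged.

Going by the values given here, with no measured step in hand, the expectation for compound 3 in this assay is none beyond the scatter: the estimated step of a number no higher from compound 2 to compound 3 (the limit leaves the size open) is set at no change, and compound 3 is expected most likely to return another limit. Compound 3 is estimated at 100000 nM, within 50000 nM to 300000 nM.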

Compound 3, minimum cytotoxic concentration: > 100000 nM
Compound 3: no number, only a limit; the forecaster's own chance of this, stated with the estimate: 85%; the middle value sits exactly at the limit.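

No step can be read between compound 2 and compound 3 in this assay, as both values are limits of the assay and not numbers: the limit of > 100000 nM in this assay, at which 3 of the 3 values shown sit.

The compounds shown leave open what size of effect, if any, hydrogen in place of methyl has in this assay, and at what concentration any of these compounds would show toxicity.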